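The compounds below may be only part of what the source reports. "The series", "measured", "known", "first", "only" and "open" are said of these compounds alone.

Measured so far:
Compound 1 `CCCCc1ccc(-c2cc(=O)c3c(o2)C(CC)(CC)C(=O)C(CC)=C3O)cc1` — 37 uM
Compound 2 `CCC1=C(O)c2c(oc(-c3ccc(CBr)cc3)cc2=O)C(CC)(CC)C1=O` — 27.9 uM

Within the data shown here, in a functional assay on KBVIN cells (Homo sapiens) for antiproliferative activity, read by sulforhodamine B assay, with a stated time of 3 days (on this read-out higher numbers stand for an effect only at larger amounts of compound and lower numbers for an effect already at smaller amounts), compound 2 gives 27.9 uM, and compound 1 gives 37 uM; the two values lie within the scatter of each other, the only step being a 1.3-fold lower number from compound 1 to compound 2 (0.12 log units; within the scatter). That step exchanges a group on the saturated chain carbon of the same phenyl ring and leaves the rest untouched.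

Compound 3 `CCC1=C(O)c2c(oc(-c3ccc(F)c(C)c3)cc2=O)C(CC)(CC)C1=O` differs from compound 2 by 4-fluoro-3-methylphenyl in place of 4-(bromomethyl)phenyl on an aromatic carbon. Among the measured compounds shown here, no measured step touches this exchange of one substituted phenyl for another; the single step available, a 1.3-fold lower number from compound 1 to compound 2 (0.12 log units; within the scatter), shows only that a change on the chain carbon of that ring stays within the scatter. With nothing pointing either way, no step beyond the scatter is expected in this assay. Compound 3 is therefore expected to give about 30 uM, with a range from 10 uM to 90 uM. This amounts to an expected step of a 1.1-fold higher number from compound 2 to compound 3 (0.03 log units; within the scatter).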

Compound 3, concentration for half-maximal effect: 1.62 uM
Compound 3: the middle estimate sits 19-fold (1.27 log units) above what was measured; the measured number lies below the stated range.
By their numbers in this assay, from the lowest: compound 3; then compounds 2 and 1 (each within the scatter of the next).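

In this assay, the aromatic carbon next to the ring oxygen proves responsive: 4-fluoro-3-methylphenyl in place of 4-(bromomethyl)phenyl gives a 17-fold lower number from compound 2 to compound 3 (1.24 log units; beyond the scatter), whereas the earlier change on the chain carbon, a 1.3-fold lower number from compound 1 to compound 2 (0.12 log units; within the scatter), stayed within the scatter. The entering and leaving groups have the same computed counts of heavy atoms, hydrogen-bond donors and acceptors, and the same net charge, so these counts do not separate them; the difference lies in which substituents the phenyl ring carries and where. Nothing available bears on why this exchange has so large an effect.

On these data alone, the exchange removes the bromomethyl group and introduces fluoro and methyl together, so it remains open whether the fluoro or the methyl alone would account for the step. As far as these compounds go, how an amine or a carboxylic acid on this phenyl ring would read out also remains open.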